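Aryl exchange on the carbonyl in a cytotoxicity series

The source may report more compounds than this note shows. Statements on the series, on what has been measured and on what is new or still open speak of the compounds shown alone.

compound 1 `COc1cc(-c2cc(/C=C/C(=O)c3ccc(Cl)c(Cl)c3)[nH]n2)cc(OC)c1OC`: 105%
compound 2 `COc1ccc(C(=O)/C=C/c2cc(-c3cc(OC)c(OC)c(OC)c3)n[nH]2)cc1`: 102%

The two measured compounds share one core and differ only in the aryl group on the carbonyl carbon. In a functional assay on ACHN cells (Homo sapiens) for cytotoxicity, read by sulforhodamine B assay, with a stated time of 48 h, tested at 0.1 uM (a higher number here means a weaker effect of the compound at the concentration tested, a lower number a stronger effect), compound 1 gives 105% and compound 2 gives 102%. Among the compounds with values here, compound 2 holds the lower of the two numbers, with compound 1 nearest, and the single measured step, a number 3 percentage points lower from compound 1 to compound 2 (within the scatter), lies within the scatter, so neither compound shows an effect at this concentration. Compound 3 `COc1cc(-c2cc(/C=C/C(=O)c3ccc(F)c(F)c3)[nH]n2)cc(OC)c1OC` has not yet been measured; it differs from compound 2 by 3,4-difluorophenyl in place of 4-methoxyphenyl on a carbonyl carbon. Within the data shown here, the only step that bears on this change is a number 3 percentage points lower from compound 1 to compound 2 (within the scatter), which exchanged 3,4-dichlorophenyl for 4-methoxyphenyl without moving beyond the scatter, so returning to a dihalogenated ring is expected to give no step beyond the scatter in this assay, a number 1 percentage points higher from compound 2 to compound 3 (within the scatter). Compound 3 is therefore estimated at 103%, with a range from 93% to 113%.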

Compound 3, a percentage reported as activity, at one concentration (the size of the read-out at that concentration, not a potency): 106%
Beside the measured number, compound 3's estimate is 3 percentage points below it, within the range that was stated.
By their numbers in this assay, from the lowest: compounds 2, 1 and 3 (each within the scatter of the next).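

Compound 3 brings a third aryl group to the carbonyl carbon, and in this assay the exchange of 4-methoxyphenyl for 3,4-difluorophenyl gives a number 4 percentage points higher from compound 2 to compound 3 (within the scatter), while the exchange of 3,4-dichlorophenyl for 3,4-difluorophenyl gives a number 1 percentage points higher from compound 1 to compound 3 (within the scatter). Within the data shown here, the flat reading at this position therefore extends beyond the one pair seen earlier: a ring with a methoxy group, a ring with two chlorines and a ring with two fluorines all stay within the scatter of one another at this single concentration. No accompanying measurement offers any account of this flat result.

Going by these compounds, whether an aminophenyl ring, a benzoic acid or a longer alkyl chain on the carbonyl carbon would move the number beyond the scatter remains open. So does the behaviour of these three compounds at other concentrations.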